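Allylsulfanyl replaces nitrobenzylsulfanyl on the shared core

The source may hold more compounds than are shown below. What is called first, only, known or untested is meant among the compounds shown, and "the series" means these compounds.

Measured compounds:
compound 1 `Cc1cc(Nc2cc(-c3ccccc3)[nH]n2)n2nc(SCc3ccc([N+](=O)[O-])cc3)nc2n1` 4250 nM
compound 2 `Cc1cc(Nc2cc(-c3ccccc3)[nH]n2)n2nc(SCc3ccc(F)cc3)nc2n1` 3270 nM
compound 3 `Cc1cc(Nc2cc(-c3ccccc3)[nH]n2)n2nc(SCCc3ccccc3)nc2n1` 5620 nM

All three numbers come from a functional assay on MGC-803 cells (Homo sapiens) for inhibition, read by MTT assay, with a stated time of 72 h; on this read-out higher numbers stand for weaker inhibition and lower numbers for stronger inhibition. Compound 1 holds the second highest of the three numbers; the nearest is compound 2, a 1.3-fold lower number from compound 1 to compound 2 (0.11 log units; within the scatter), and the furthest is compound 3, a 1.3-fold higher number from compound 1 to compound 3 (0.12 log units; within the scatter). Compound 2 and compound 3 lie a 1.7-fold higher number from compound 2 to compound 3 (0.24 log units; within the scatter). The set therefore shows no step beyond the scatter at all.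

Compound 4 `C=CCSc1nc2nc(C)cc(Nc3cc(-c4ccccc4)[nH]n3)n2n1` is not yet measured. Against compound 1 the difference is vinyl in place of 4-nitrophenyl on a saturated chain carbon bound to a sulfur. Going by the values given here, two measured steps bear on the same place: a change of the substituent on the ring in this assay gave a 1.3-fold lower number from compound 1 to compound 2 (0.11 log units; within the scatter), and a lengthening of the chain to benzyl gave a 1.3-fold higher number from compound 1 to compound 3 (0.12 log units; within the scatter). Neither removed the aromatic ring, as the step to compound 4 does, so it is less covered than either. On what is shown, no movement beyond the scatter is expected; compound 4 is estimated at 5500 nM, range 2500 nM to 12000 nM, which means an expected 1.3-fold higher number from compound 1 to compound 4 (0.11 log units; within the scatter).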

Compound 4, half-maximal inhibitory concentration: 17200 nM
For compound 4 the middle estimate is 3.1-fold (0.50 log units) below the measured one, outside the stated range (above it).
By their numbers in this assay, from the lowest: compounds 2, 1 and 3 (each within the scatter of the next); then compound 4.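

In this assay the position on a saturated chain carbon bound to a sulfur proves not to be indifferent: the three compounds carrying an aromatic ring there lie within the scatter of one another, whereas the allyl compound stands apart, with a 4.0-fold higher number from compound 1 to compound 4 (0.61 log units; beyond the scatter) and a 3.1-fold higher number from compound 3 to compound 4 (0.49 log units; beyond the scatter) and also a 5.3-fold higher number from compound 2 to compound 4 (0.72 log units; beyond the scatter) in the same direction. Going by these compounds alone, this change removes the six-membered aromatic ring and shrinks the group as well, so the one compound without that ring is the only sign so far that the ring matters at this position. Nothing available explains the loss.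

Open, as far as these compounds go, is whether the ring itself or simply the size of the group counts, which a cyclohexylmethyl group or a longer alkyl chain on the sulfur would separate. Also open, from the compounds shown here alone, is how a terminal amine or carboxylic acid on a short chain there would read.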